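This account rests on a few compounds, and the source may have more. Where it says the series, first, only, none or still open, it means among the compounds named here.

Measured in a functional assay on DU-145 cells (Homo sapiens) for antiproliferative activity, read by MTT assay, with a stated time of 72 h; on this read-out higher numbers stand for weaker inhibition and lower numbers for stronger inhibition:
Compound 1 `O=C(O)/C=C/c1ccc(-c2ccc(F)cc2)c(Cl)c1`: > 100000 nM (a limit)
Compound 2 `CC(C)(C)C#Cc1cc(-c2ccc(/C=C/C(=O)O)cc2Cl)ccc1O`: > 10000 nM (a limit)

Neither compound has an exact number in this assay. Compound 2 is known only by its limit of > 10000 nM.

Compound 3 `CC1(c2cc(-c3ccc(/C=C/C(=O)O)cc3Cl)ccc2O)CCCCC1` keeps the rest of compound 2 and changes one group: 1-methylcyclohexyl in place of 3,3-dimethylbut-1-yn-1-yl on an aromatic carbon. In words, 1-methylcyclohexyl stands in place of 3,3-dimethylbut-1-yn-1-yl on an aromatic carbon, ortho to a hydroxy group. A triple bond outside aromatic rings gives way to a six-membered non-aromatic ring of carbon only.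

Within the data shown here, no measured pair shows what a change at this place does, so the expectation is loose. A modest move towards stronger inhibition in this assay is expected, though another limit remains quite possible. The expected change is an at least 1.6-fold lower number from compound 2 to compound 3 (0.22 log units; that floor lies within the scatter). For compound 3, the estimated value is 6000 nM, with an expected range from 1200 nM to 25000 nM.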

Compound 3, half-maximal inhibitory concentration: 8000 nM
For compound 3 the middle estimate is 1.3-fold (0.12 log units) below the measured one, and the stated range covers the measured number.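

In this assay, putting 1-methylcyclohexyl in place of 3,3-dimethylbut-1-yn-1-yl on this aromatic carbon, ortho to a hydroxy group, gives an at least 1.2-fold lower number from compound 2 to compound 3 (0.09 log units; that floor lies within the scatter). Compound 3, at 8000 nM, is the first compound shown with an exact number, so a six-membered non-aromatic ring of carbon only can stand at this place without losing a measurable read-out. The true size of the step stays unknown, and a real gain is not established, since compound 2 rests only on a limit: the limit of > 10000 nM in this assay, at which 1 of the 3 values shown sits.

Going by these compounds, what an amine or a longer straight carbon chain would do on this same aromatic carbon remains open. So does whether any group at this place can bring the number much lower than that of compound 3.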